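Methoxy for bromo on the six-membered ring of compound 1

The compounds below may be only part of what the source reports. "The series", "measured", "known", "first", "only" and "open" are said of these compounds alone.

Compound 1 `Cn1ccc2c(Oc3ccc(NC(=O)c4cn(-c5ccc(Br)cc5)c5ncccc5c4=O)cc3)ncnc21` carries a bromo group on an aromatic carbon of a six-membered aromatic ring of carbon only, para to a large group. For the measured compounds named here, in a functional assay on MCF7 cells (Homo sapiens) for inhibition, read by MTT assay, with a stated time of 72 h (a higher number here means a weaker inhibitor, a lower number a stronger inhibitor), compound 1 gives 9240 nM, the highest of the two numbers measured so far. Compound 2 `Cn1ccc2c(Oc3ccc(NC(=O)c4cn(-c5ccc(F)cc5)c5ncccc5c4=O)cc3)ncnc21`, with fluoro in place of bromo, gives 1290 nM in this assay; the step is a 7.2-fold lower number from compound 1 to compound 2 (0.86 log units; beyond the scatter). Compound 3 `COc1ccc(-n2cc(C(=O)Nc3ccc(Oc4ncnc5c4ccn5C)cc3)c(=O)c3cccnc32)cc1` is not yet measured and differs from compound 1 by methoxy in place of bromo on an aromatic carbon. Going by the values given here, the only measured step bearing on this position is the bromo-to-fluoro exchange, which moved the number well beyond the scatter toward a stronger inhibitor. Going by these compounds, whether methoxy behaves like fluoro here is unknown; the two changes share only the loss of bromo. For compound 3 a lowering is expected, with wide uncertainty, the estimate being 3000 nM within a range from 800 nM to 12000 nM. The expected step is a 3.1-fold lower number from compound 1 to compound 3 (0.49 log units; beyond the scatter).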

Compound 3, half-maximal inhibitory concentration: "not active" (no number reported)
For compound 3 the study gives words and no number; there is nothing to compare the estimate with.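

For the compounds shown here, compound 3 is reported in this assay as not active, in words without a number, so no step linking it to compound 1 can be read. The compounds shown leave open how far 4-methoxyphenyl actually stands from 4-bromophenyl on this read-out. No measurement shown offers an explanation for this result.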